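A few compounds are considered here, and "the series" means these few. Any claim that something is new, unique, unknown or untested is made for them only; others in the source may bear on it.

Among the measured compounds shown here, compound 2 `CCC(=O)N1N=C(c2ccccc2)CC1c1ccc(F)cc1` stands at the higher of the two numbers measured so far: in an assay on isolated protein for inhibition of Amine oxidase [flavin-containing] A (Bos taurus) (on this read-out higher numbers stand for weaker inhibition and lower numbers for stronger inhibition), compound 2 gives 7240 nM. For the measured compounds named here, its only measured neighbour is compound 1 `CCC(=O)N1N=C(c2ccccc2)CC1c1ccc(Cl)cc1`, which in this assay gives 200 nM; the step of a 36-fold higher number from compound 1 to compound 2 (1.56 log units; beyond the scatter) is the one measured change between them, a fluoro in place of chloro on an aromatic carbon. Compound 3 `CCC(=O)N1N=C(c2ccccc2)CC1c1ccc(C)cc1` has not yet been measured. It differs from compound 2 by methyl in place of fluoro on an aromatic carbon. No measured step involves a methyl, so nothing shown covers this change directly; the single step that touches the same aromatic carbon was large. Because a 36-fold higher number from compound 1 to compound 2 (1.56 log units; beyond the scatter) showed that this assay answers strongly to which group sits on that aromatic carbon, a further change of that group is expected to move the number again, and the expected direction is toward a lower number, a step of an 8.0-fold lower number from compound 2 to compound 3 (0.91 log units; beyond the scatter). Compound 3 is therefore estimated at 900 nM, with a range from 200 nM to 4000 nM.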

Compound 3, half-maximal inhibitory concentration: 75900 nM
Compound 3: middle estimate off by 84-fold (1.93 log units), on the low side, and the stated range ends below it.
By their numbers in this assay, from the lowest: compound 1; then compound 2; then compound 3.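

In this assay, replacing fluoro with methyl on this aromatic carbon does not recover activity: the step of a 10-fold higher number from compound 2 to compound 3 (1.02 log units; beyond the scatter) goes the same way as the earlier change from chloro to fluoro, and the step of a 380-fold higher number from compound 1 to compound 3 (2.58 log units; beyond the scatter) is the largest of the three in this small set. Fluoro and methyl are each counted as one heavy atom with no ring, no hydrogen-bond donors or acceptors and no net charge, yet compound 2 and compound 3 lie beyond the scatter of each other, so those counts do not predict the number at this position. Nothing measured here explains why chloro gives the lowest of the three numbers, fluoro the middle one and methyl the highest.

With only these three groups shown, it remains open whether bromo, methoxy, an amine or a nitrile on the same carbon would give a number lower than that of compound 1 or fall among the other two. On these data alone, it also remains open whether the same order of chloro, fluoro and methyl would hold if the propanoyl group or the unsubstituted phenyl ring of the shared core were replaced.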